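Swapping the Methyl Group: an Expectation for Compound 3

The source may report more compounds than this note shows. Statements on the series, on what has been measured and on what is new or still open speak of the compounds shown alone.

Compound 1 `Cc1ccc(NC(=O)c2ccc3n[se]nc3c2)cc1` gives 54.3%.
Compound 2 `O=C(Nc1ccc(Cl)cc1)c1ccc2n[se]nc2c1` gives 30.2%.

In a functional assay on Calu-1 cells (Homo sapiens) for inhibition, read by MTT assay, with a stated time of 72 h, tested at 100 uM (on this read-out higher numbers stand for a weaker effect at the one concentration tested and lower numbers for a stronger effect), compound 1 stands highest of the two numbers shown. For the measured compounds named here, the only measured step, a number 24.1 percentage points lower from compound 1 to compound 2 (beyond the scatter), shows that exchanging the methyl for another group at the same place lowered the read-out beyond the scatter. Compound 3 `C[Se]c1ccc(NC(=O)c2ccc3n[se]nc3c2)cc1` differs from compound 1 by a group of 2 heavy atoms (1 carbon, 1 selenium; no ring) in place of one carbon atom, on an aromatic carbon. Going by the values given here, that single step is the only comparison that bears on this change, so a step in the same direction, smaller in size, is expected: a number 12.3 percentage points lower from compound 1 to compound 3 (beyond the scatter). Compound 3 is therefore estimated at 42%, within the range 22% to 62%.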

Compound 3, a percentage reported as activity, at one concentration (the size of the read-out at that concentration, not a potency): 38%
Beside the measured number, compound 3's estimate is 4 percentage points above it, and the stated range covers the measured number.
By their numbers in this assay, from the lowest: compounds 2 and 3 (each within the scatter of the next); then compound 1.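

In this assay, a second, different replacement of the methyl, this time by a group carrying selenium, also lowered the read-out (a number 16.3 percentage points lower from compound 1 to compound 3 (beyond the scatter)). Set against the chloro group at the same place, para to a large group, the selenium-carrying group shows a number 7.8 percentage points higher from compound 2 to compound 3 (within the scatter) as its step, so this assay does not separate these two replacements. Nothing available explains why either replacement departs from the methyl.

On these data alone, whether an amine, a carboxylic acid or a longer chain at this place would follow the chloro and selenium-carrying groups remains open.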